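Ethyl in Place of tert-Butyl on the Shared Core

This account rests on a few compounds, and the source may have more. Where it says the series, first, only, none or still open, it means among the compounds named here.

Measured so far in an assay on CHO cells, read by calcium flux; on this read-out higher numbers stand for weaker inhibition and lower numbers for stronger inhibition:
compound 1 `CC(C)c1ccc(NC(=O)c2csc(Cc3c(Cl)cccc3Cl)n2)cc1` gives 370 nM
compound 2 `CC(C)(C)c1ccc(NC(=O)c2csc(Cc3c(Cl)cccc3Cl)n2)cc1` gives 570 nM

Compound 2 has the highest of the two numbers, its nearest neighbour being compound 1, with a 1.5-fold higher number from compound 1 to compound 2 (0.19 log units; within the scatter). Compound 3 `CCc1ccc(NC(=O)c2csc(Cc3c(Cl)cccc3Cl)n2)cc1` has not been measured; it differs from compound 2 by ethyl in place of tert-butyl on an aromatic carbon. Going by the values given here, the only step that bears on it is the one from compound 1 to compound 2, which also changed the same saturated chain and stayed within the scatter. A further trim of that chain is therefore expected to move the number little in this assay, if at all. Compound 3 is estimated at 450 nM, between 200 nM and 1000 nM, an expected step of a 1.3-fold lower number from compound 2 to compound 3 (0.10 log units; within the scatter).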

Compound 3, half-maximal inhibitory concentration: 810 nM
Compound 3: the middle estimate sits 1.8-fold (0.26 log units) below what was measured, within the range that was stated.
By their numbers in this assay, from the lowest: compounds 1, 2 and 3 (each within the scatter of the next, the first and the last beyond it).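

In this assay, ethyl in place of tert-butyl on this aromatic carbon stays within the scatter, with a 1.4-fold higher number from compound 2 to compound 3 (0.15 log units; within the scatter) as its step. Compared with compound 1, however, ethyl gives the only step beyond the scatter so far, a 2.2-fold higher number from compound 1 to compound 3 (0.34 log units; beyond the scatter) as a modest step, so this position does respond to small changes in the chain, though tert-butyl in compound 2 lies within the scatter of both others. Nothing available explains this difference.

Still open, on these data alone, is how this position responds to a group other than a saturated chain, such as an amine or a carboxylic acid.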